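The source may hold more compounds than are shown below. What is called first, only, known or untested is meant among the compounds shown, and "the series" means these compounds.

Measured in an ADME assay on HaCaT cells (Homo sapiens) for cytotoxicity, read by MTT assay, with a stated time of 48 h (a higher number here means a weaker inhibitor, a lower number a stronger inhibitor), so far
- compound 1 `Fc1ccc(-c2nn(-c3ccccc3)cc2-c2nc3cc(Cl)ccc3[nH]2)cc1` gives > 50000 nM as a limit of the assay, not a number
- compound 2 `Fc1ccc(-c2nn(-c3ccccc3)cc2-c2nc3cc(Cl)c(Cl)cc3[nH]2)cc1` gives 44600 nM
- compound 3 `FC(F)(F)c1ccc2[nH]c(-c3cn(-c4ccccc4)nc3-c3ccc(Cl)cc3)nc2c1` gives 41800 nM

Compound 2 at 44600 nM lies within the scatter of compound 3 at 41800 nM and has no third number to be compared with.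

The next compound is compound 4 `Clc1ccc(-c2nn(-c3ccccc3)cc2-c2nc3cc(Cl)c(Cl)cc3[nH]2)cc1` with chloro in place of fluoro on an aromatic carbon, para to a large group chloro in place of fluoro on an aromatic carbon and read one bond further out as 4-fluorophenyl to 4-chlorophenyl.

Within the data shown here, the only measured step, an at least 1.1-fold lower number from compound 1 to compound 2 (0.04 log units; that floor lies within the scatter) (chloro in place of hydrogen on an aromatic carbon), is a different exchange and gives only a weak guide. That step starts from the limit of > 50000 nM in this assay, at which 1 of the 3 values shown sits, and so fixes no exact size.

The expected step is a 1.1-fold lower number from compound 2 to compound 4 (0.05 log units; within the scatter) in this assay and no move beyond the scatter is expected. For compound 4 the estimate is 40000 nM with an expected range from 20000 nM to 60000 nM and some expected chance of a limit in place of a number.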

Compound 4, half-maximal inhibitory concentration: > 50000 nM
Compound 4: a limit, no number; the forecaster's own chance of this, stated with the estimate: 30%; middle value at least 1.2-fold (0.09 log units) from the limit.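

In this assay, 4-chlorophenyl in place of 4-fluorophenyl gives an at least 1.1-fold higher number from compound 2 to compound 4 (0.04 log units; that floor lies within the scatter). Compound 4 gives > 50000 nM, which is a limit of the assay and not a number. This is the first reading of a change on this aromatic carbon, para to a large group, and it gives only a floor for the step, so no change of real size can be read here yet, and the limit now holds for more of the series: the limit of > 50000 nM in this assay, at which 2 of the 4 values shown sit.

Going by these compounds, it stays open how the shared core reads in this assay with an amine, a carboxylic acid or a methoxy group at this place in place of the halogen. Whether any group there moves the number beyond the scatter also remains unanswered.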